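Estimating compound 3 from compound 2

This account rests on a few compounds, and the source may have more. Where it says the series, first, only, none or still open, it means among the compounds named here.

Measured in a functional assay on LoVo cells (Homo sapiens) for inhibition, read by MTT assay, with a stated time of 48 h; a lower number here means a stronger inhibitor, a higher number a weaker inhibitor
- Compound 1 `COc1ccc(N(C)c2nc(C)nc3ccccc23)cc1OCCC[Se]C#N` gives 921 nM
- Compound 2 `COc1ccc(N(C)c2nc(C)nc3ccccc23)cc1C(=O)OCCC[Se]C#N` gives 854 nM

Compound 2 at 854 nM stands level with compound 1, within the usual scatter of repeated measurements. Compound 3 `COc1ccc(N(C)c2nc(C)nc3ccccc23)cc1C(=O)OCCCC[Se]C#N` differs from compound 2 in one place: a group of 4 heavy atoms (2 carbon, 1 nitrogen, 1 selenium; no ring) in place of a group of 3 heavy atoms (1 carbon, 1 nitrogen, 1 selenium; no ring), on a saturated chain carbon, three bonds along the chain from an oxygen next to a carbonyl group and the rest of the molecule stays the same.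

Within the data shown here, only one measured step bears on this, and only loosely: a 1.1-fold lower number from compound 1 to compound 2 (0.03 log units; within the scatter) for a change on an aromatic carbon, not on a saturated chain carbon. Among the measured compounds shown here, no measured pair shows a change at the new place, so the data point in no direction. In this assay the expected step is a 1.0-fold lower number from compound 2 to compound 3 (0.00 log units; within the scatter) and no shift beyond the scatter is expected. Compound 3 is estimated at 850 nM with 400 nM to 1800 nM as the expected range.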

Compound 3, half-maximal inhibitory concentration: 1080 nM
Beside the measured number, compound 3's estimate is 1.3-fold (0.10 log units) below it; measured number inside the range.
By their numbers in this assay, from the lowest: compounds 2, 1 and 3 (each within the scatter of the next).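

Among these compounds, this is the first measured change on the saturated chain itself. In this assay, a group of 4 heavy atoms in place of a group of 3 heavy atoms gives a 1.3-fold higher number from compound 2 to compound 3 (0.10 log units; within the scatter), and the larger replacement on the aromatic carbon gives a 1.2-fold higher number from compound 1 to compound 3 (0.07 log units; within the scatter), so neither change moves the number beyond the scatter and all three compounds stand level. No supporting measurement bears on this result.

The compounds shown leave open whether a much longer chain at this position would also leave the number level. They also do not show what happens when an amine or a carboxylic acid takes the place of the selenium-bearing nitrile end of the chain.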